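Notes on replacing 3-chlorobenzyl with 3-hydroxyphenyl

The source may hold more compounds than are shown below. What is called first, only, known or untested is meant among the compounds shown, and "the series" means these compounds.

Measured so far in a functional assay on HCC827 cells (Homo sapiens) for inhibition, read by fluorescence, with a stated time of 72 h; on this read-out lower numbers stand for stronger inhibition of growth and higher numbers for weaker inhibition of growth:
- compound 1 `CCCCn1cnc2c(NCc3cccc(Cl)c3)nc(N[C@H]3CC[C@H](N)CC3)nc21`: 10600 nM
- compound 2 `CC(C)CCn1cnc2c(NCc3cccc(Cl)c3)nc(N[C@H]3CC[C@H](N)CC3)nc21`: 16700 nM

Among the measured compounds shown here, compound 2 stands at 16700 nM, level within the scatter with the only other number: a 1.6-fold higher number from compound 1 to compound 2 (0.20 log units; within the scatter). Next comes compound 3 `CC(C)CCn1cnc2c(Nc3cccc(O)c3)nc(N[C@H]3CC[C@H](N)CC3)nc21`, with 3-hydroxyphenyl in place of 3-chlorobenzyl on a nitrogen on an aromatic ring. For the measured compounds named here, the one measured step lies on the saturated chain and leaves the (3-chlorobenzyl)amino group untouched, so it bears only weakly on this change. Going by the values given here, no measured step covers the new group, and the data set no direction in this assay. No step beyond the scatter is therefore expected, and the range stays wide on both sides. Compound 3 is expected at 10000 nM, with an estimated range from 2000 nM to 40000 nM. The estimated step is a 1.7-fold lower number from compound 2 to compound 3 (0.22 log units; within the scatter).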

Compound 3, concentration for 50% growth inhibition: 21300 nM
Compound 3: middle estimate off by 2.1-fold (0.33 log units), on the low side, within the range that was stated.
By their numbers in this assay, from the lowest: compounds 1, 2 and 3 (each within the scatter of the next).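

In this assay, the first step read at this position, 3-hydroxyphenyl in place of 3-chlorobenzyl on a nitrogen on an aromatic ring, gives a 1.3-fold higher number from compound 2 to compound 3 (0.11 log units; within the scatter). The group at this position can therefore go from a chlorine-bearing benzyl without hydrogen-bond donors or acceptors to a smaller hydroxyl-bearing phenyl that has them, and the growth-inhibition number stays level within the scatter. No available evidence accounts for this result.

Among the compounds shown here, the single step changes the ring substituent and the benzyl-to-phenyl form together, so the contribution of each remains unresolved; 3-chlorophenyl or 3-hydroxybenzyl on the same nitrogen would separate them. As far as these compounds go, it also remains open whether a different group there, such as 3-aminophenyl or 3-carboxyphenyl, would move the number beyond the scatter.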